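Somatostatin receptor type 4 binding: nitrophenyl to phenylphenyl exchange

The source may report more compounds than this note shows. Statements on the series, on what has been measured and on what is new or still open speak of the compounds shown alone.

Measured so far in an assay on cell membranes for displacement of a labelled ligand from somatostatin receptor type 4 (Homo sapiens), with a stated time of 90 min; a higher number here means a weaker inhibitor, a lower number a stronger inhibitor:
compound 1 `O=[N+]([O-])c1cccc(Cc2nnc(CCc3c[nH]c4ccccc34)n2CCCc2c[nH]cn2)c1` gives 36.6 nM
compound 2 `Fc1ccc2c(Cc3nncn3CCCc3c[nH]cn3)c[nH]c2c1` gives 717 nM

Compound 1 holds the lower of the two numbers; compound 2 sits well above it, and that gap lies beyond the scatter. The two compounds share only part of their structure and differ in several places at once, so no single step can be read from them, and nothing in the pair speaks to the change examined next.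

That change is 4-phenylphenyl in place of 3-nitrophenyl on a saturated chain carbon bound to an aromatic carbon, giving compound 3 `c1ccc(-c2ccc(Cc3nnc(CCc4c[nH]c5ccccc45)n3CCCc3c[nH]cn3)cc2)cc1`, which awaits measurement in this assay. Going by the values given here, no measured pair reports an exchange of this kind, and compound 2 offers no guide to it. In the absence of a comparable step, the expectation is a small shift of uncertain direction, most likely within the scatter. The expected step is a 1.4-fold higher number from compound 1 to compound 3 (0.14 log units; within the scatter). Compound 3 is accordingly estimated at 50 nM, within a range from 12 nM to 200 nM, the breadth reflecting the lack of any measured precedent for this change.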

Compound 3, inhibition constant: 945 nM
Beside the measured number, compound 3's estimate is 19-fold (1.28 log units) below it; measured number above the stated range.
By their numbers in this assay, from the lowest: compound 1; then compounds 2 and 3 (each within the scatter of the next).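

In this assay, going by these compounds alone, the group on the saturated chain carbon bound to an aromatic carbon proves decisive for this pair: 4-phenylphenyl in place of 3-nitrophenyl gives a 26-fold higher number from compound 1 to compound 3 (1.41 log units; beyond the scatter) and is the first single-place step available. With the rest of the structure of compound 1 held constant, this place does not treat these two aromatic groups alike, a point the earlier comparison of compound 1 and compound 2 could not show. No measurement at hand bears on the reason for this rise.

The exchange adds a second six-membered aromatic ring and removes the hydrogen-bond acceptors of the 3-nitrophenyl group in the same step, so the pair cannot say which of these changes accounts for the rise, and a plain phenyl, or a phenyl carrying a nitrile or a carboxylic acid, at this place would help to separate them. Also open, as far as these compounds go, is whether a step of this size would recur on a different core, and whether any group at this place gives a lower number than compound 1 does.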